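Purine series: removing a ring chloro from compound 2

The source may hold more compounds than are shown below. What is called first, only, known or untested is meant among the compounds shown, and "the series" means these compounds.

Compound 1 `ClCc1ccccc1Cn1cnc2c(Cl)ncnc21`: 9550 nM
Compound 2 `ClCc1ccc(Cn2cnc3nc(Cl)nc(Cl)c32)cc1`: 3010 nM

Among the compounds with values here, in a functional assay on MDA-MB-435 cells (Homo sapiens) for cytotoxicity, read by sulforhodamine B assay, with a stated time of 48 h (on this read-out higher numbers stand for weaker inhibition of growth and lower numbers for stronger inhibition of growth), compound 2 gives 3010 nM, the lowest of the two numbers, and compound 1 gives 9550 nM, a gap beyond the scatter; the two differ in more than one place, so no single step can be drawn from them. Compound 3 `ClCc1ccc(Cn2cnc3ncnc(Cl)c32)cc1` differs from compound 2 by hydrogen in place of chloro on an aromatic carbon, on the carbon between two ring nitrogen atoms of the shared core. Without a clean precedent, a small loss is expected, a 1.8-fold higher number from compound 2 to compound 3 (0.26 log units; within the scatter). Compound 3 is estimated at 5500 nM, within 2000 nM to 15000 nM.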

Compound 3, concentration for total growth inhibition: 19100 nM
Compound 3: middle estimate off by 3.5-fold (0.54 log units), on the low side, and the stated range ends below it.
By their numbers in this assay, from the lowest: compound 2; then compounds 1 and 3 (each within the scatter of the next).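

Within the data shown here, the first single-place step falls on the carbon between two ring nitrogen atoms: in this assay, hydrogen in place of chloro gives a 6.3-fold higher number from compound 2 to compound 3 (0.80 log units; beyond the scatter). The chloro here therefore counts for growth inhibition in this pair, even though compound 3 keeps its other chloro on the same ring. Nothing given here accounts for the size of this step.

The compounds shown leave open whether an amine or a methoxy group on this carbon would match compound 2 or fall nearer compound 3.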